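The source may hold more compounds than are shown below. What is called first, only, known or untested is meant among the compounds shown, and "the series" means these compounds.

Measured compounds in a functional assay on NCI-H460 cells (Homo sapiens) for cytotoxicity, read by MTT assay, with a stated time of 72 h; on this read-out lower numbers stand for stronger inhibition and higher numbers for weaker inhibition:

compound 1, `COc1cc2c(Oc3ccc(NC(=O)c4cc(-c5ccccc5)ccn4)cc3F)ccnc2cc1OCCCN1CCN(C)CC1`, gives 91 nM
compound 2, `COc1cc2c(Oc3ccc(NC(=O)c4cc(-c5ccccc5F)ccn4)cc3F)ccnc2cc1OCCCN1CCN(C)CC1`, gives 140 nM
compound 3, `COc1cc2c(Oc3ccc(NC(=O)c4nccc(-c5ccc(F)cc5)n4)cc3F)ccnc2cc1OCCCN1CCCCC1`, gives 240 nM

Compounds 1 and 2 share one core; compound 3 has a different core, and the difference between the two cores is not broken down here. Among the compounds with values here, the only single-point change that has been measured is the one from compound 1 to compound 2: fluoro in place of hydrogen on an aromatic carbon. It gave a 1.5-fold higher number from compound 1 to compound 2 (0.19 log units; within the scatter), so the two values cannot be ordered against each other. Compound 3 sits within the scatter of compound 2 but beyond it against compound 1.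

Compound 4, `COc1cc2c(Oc3ccc(NC(=O)c4nccc(-c5ccc(F)cc5F)n4)cc3F)ccnc2cc1OCCCN1CCCCC1`, has not yet been measured in this assay. It differs from compound 3 by fluoro in place of hydrogen on an aromatic carbon. Within the data shown here, this is the same kind of change as the one from compound 1 to compound 2, not the same: in compound 4 the entering fluoro stands ortho to a large group and also meta to a fluoro group, whereas in compound 2 it stands ortho to a large group only, and the cores differ.

With a single earlier instance, the expectation for compound 4 rests on compound 3 at 240 nM and on the earlier step of a 1.5-fold higher number from compound 1 to compound 2 (0.19 log units; within the scatter), which stayed within the scatter. The step from compound 3 to compound 4 is therefore expected to be small, around a 1.3-fold higher number from compound 3 to compound 4 (0.12 log units; within the scatter), with wide uncertainty because the cores differ. Compound 4 is estimated at 320 nM, between 150 nM and 700 nM.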

Compound 4, half-maximal inhibitory concentration: 550 nM
Estimate against measurement, compound 4: 1.7-fold (0.24 log units) below; the range from low to high includes it.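

In this assay, fluoro in place of hydrogen on an aromatic carbon, read here as 4-fluorophenyl to 2,4-difluorophenyl, gives a 2.3-fold higher number from compound 3 to compound 4 (0.36 log units; beyond the scatter). Set beside the earlier instance of this change, the step shows no difference in size that can be told apart between the two cores: the same change on two cores in this assay, a 1.5-fold higher number (0.19 log units; within the scatter) from compound 1 to compound 2 and a 2.3-fold higher number (0.36 log units; beyond the scatter) from compound 3 to compound 4, 1.5-fold (0.17 log units) apart, within the scatter of two such steps. Within the data shown here, this does not show that the step has a fixed size across the series: it rests on only two pairs, just one of the two steps lies beyond the scatter, and the entering fluoro stands ortho to a large group in both compound 2 and compound 4 but meta to a fluoro group only in compound 4, leaving the effect of the core and that of the surroundings unseparated.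

The compounds shown leave open whether the same step appears on the core of compound 3 when no fluoro group is already present on that aromatic ring, and whether it holds on any third core. They also leave open whether chloro, methyl or nitrile in place of the same hydrogen would give a step like that of fluoro.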